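A few compounds are considered here, and "the series" means these few. Any claim that something is new, unique, unknown or untested is made for them only; others in the source may bear on it.

Measured so far in an ADME assay on BJ cells (Homo sapiens), read by MTT assay, with a stated time of 72 h; a higher number here means a weaker inhibitor, a lower number a stronger inhibitor:
Compound 1 `CNc1ncnc2c1c(-c1ccco1)cn2[C@@H]1O[C@H](CO)[C@@H](O)[C@H]1O`: 5040 nM
Compound 2 `CNc1ncnc2c1c(-c1cccs1)cn2[C@@H]1O[C@H](CO)[C@@H](O)[C@H]1O`: > 100000 nM

Compound 1, which carries furan-2-yl, gives a measured number. Compound 2, which carries thiophen-2-yl, gives only a limit and not a number, so its place is known only as the limit of > 100000 nM in this assay, at which 1 of the 2 values shown sits.

Compound 3 `CNc1ncnc2c1c(-c1ccsc1)cn2[C@@H]1O[C@H](CO)[C@@H](O)[C@H]1O` remains to be measured. It has thiophen-3-yl in place of thiophen-2-yl on an aromatic carbon of the shared core: thiophen-3-yl in place of thiophen-2-yl on an aromatic carbon. The two compounds have the same atoms, joined differently.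

Within the data shown here, only one measured step bears on this change. That step, an at least 19-fold higher number from compound 1 to compound 2 (1.29 log units; beyond the scatter), is large and lies beyond the scatter, and it shows that the group at this place can matter in this assay. However, it swaps one ring for another, whereas here the thiophene stays and only its point of attachment moves. Among the measured compounds shown here, no measured step shows such a move, so the size of the step is uncertain. A modest move towards a lower number is expected, though compound 3 may well stay at the limit.

The estimated step is an at least 1.6-fold lower number from compound 2 to compound 3 (0.22 log units; that floor lies within the scatter). Compound 3 is expected at 60000 nM, within an estimated range of 10000 nM to 150000 nM.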

Compound 3, half-maximal inhibitory concentration: > 100000 nM
Compound 3: only a limit was reported; the forecaster's own chance of this, stated with the estimate: 60%; middle value at least 1.6-fold (0.22 log units) from the limit.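

In this assay, moving the thiophene's point of attachment gives no readable change: compound 2 and compound 3 each rest at a limit of the assay, not at a number, and the step between them cannot be read. Thiophen-3-yl in place of furan-2-yl gives an at least 19-fold higher number from compound 1 to compound 3 (1.29 log units; beyond the scatter), so the large step seen earlier is not confined to thiophen-2-yl. Both thiophene attachments therefore part from furan-2-yl in the same direction, and compound 1 is the only one of the three with a measured number rather than a limit: the limit of > 100000 nM in this assay, at which 2 of the 3 values shown sit.

Going by these compounds, whether thiophen-2-yl and thiophen-3-yl truly differ stays open, for neither has a number that could be compared with the other. The compounds shown also leave open how a phenyl ring, an amine or a carboxylic acid at this place would read in this assay, and whether any such group would give a number lower or higher than that of compound 1.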